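Stretching the Amino Group on a Chemokine Receptor Antagonist

The source may hold more compounds than are shown below. What is called first, only, known or untested is meant among the compounds shown, and "the series" means these compounds.

Three compounds share one core. Compound 1 `COc1nn(C)c2nc(C)nc(NS(=O)(=O)c3cccc(Cl)c3Cl)c12` gives 631 nM in a functional assay on cells for antagonist activity at C-C chemokine receptor type 4 (Homo sapiens), read by GTPgammaS binding (on this read-out higher numbers stand for weaker inhibition and lower numbers for stronger inhibition), compound 2 `COc1nc(NS(=O)(=O)c2cccc(Cl)c2Cl)c2c(OC)nn(C)c2n1` gives 794 nM, and compound 3 `CNc1nc(NS(=O)(=O)c2cccc(Cl)c2Cl)c2c(OC)nn(C)c2n1` gives 79.4 nM. Compound 3 stands lowest of the three: the steps of a 7.9-fold lower number from compound 1 to compound 3 (0.90 log units; beyond the scatter) and a 10-fold lower number from compound 2 to compound 3 (1.00 log units; beyond the scatter) both lie beyond the scatter, while a 1.3-fold higher number from compound 1 to compound 2 (0.10 log units; within the scatter) does not. Compound 4 `COc1nn(C)c2nc(NC(C)C)nc(NS(=O)(=O)c3cccc(Cl)c3Cl)c12` differs from compound 3 by isopropyl in place of methyl on a nitrogen on an aromatic ring. For the measured compounds named here, none of the measured steps changes the size of the group on this nitrogen; they only show that methylamino works better than methyl or methoxy at that carbon. A shift within the scatter is therefore expected in this assay. The expected step is a 1.0-fold higher number from compound 3 to compound 4 (0.00 log units; within the scatter). Compound 4 is expected to give 80 nM, between 25 nM and 250 nM.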

Compound 4, half-maximal inhibitory concentration: 3160 nM
The estimate for compound 4 lay 40-fold (1.60 log units) below the measured number, outside the stated range (above it).
By their numbers in this assay, from the lowest: compound 3; then compounds 1 and 2 (each within the scatter of the next); then compound 4.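

In this assay the step of a 40-fold higher number from compound 3 to compound 4 (1.60 log units; beyond the scatter) shows that the group on this nitrogen matters: the advantage of methylamino is lost when isopropyl replaces its methyl. The steps of a 4.0-fold higher number from compound 2 to compound 4 (0.60 log units; beyond the scatter) and a 5.0-fold higher number from compound 1 to compound 4 (0.70 log units; beyond the scatter) show that isopropylamino does worse at this carbon than methoxy or methyl, so a nitrogen attached there does not by itself secure a low number. Nothing available here explains this loss. The compounds shown leave open how a plain amino group, ethylamino or cyclopropylamino would behave at this carbon.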